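The source may hold more compounds than are shown below. What is called first, only, known or untested is meant among the compounds shown, and "the series" means these compounds.

Compound 3 `COc1cc2c(Oc3c(F)cc(NC(=O)NN4C(=O)CSC4c4c(F)cccc4F)cc3F)ccnc2cc1OCCCN1CCC(C)CC1` gives 970 nM in a functional assay on A549 cells (Homo sapiens) for antiproliferative activity, read by MTT assay, with a stated time of 72 h (a lower number here means a stronger inhibitor, a higher number a weaker inhibitor), the lowest of the two numbers in hand. Compound 1 `COc1cc2c(Oc3ccc(NC(=O)NN4C(=O)CSC4c4c(F)cccc4F)c4ccccc34)ccnc2cc1OCCCN1CCCC1` gives 2360 nM in this assay. Compound 2 `COc1cc2c(Oc3c(F)cc(NC(=O)NN4C(=O)CSC4c4c(F)cccc4F)cc3F)ccnc2cc1OCCCN1CCc2sccc2C1` reaches only the limit of > 20000 nM in this assay. Compound 4 `COc1cc2c(Oc3c(F)cc(NC(=O)NN4C(=O)CSC4c4c(F)cccc4F)cc3F)ccnc2cc1OCCCN1CCC(N2CCCCC2)CC1` differs from compound 3 in one place: piperidin-1-yl in place of methyl on a saturated ring carbon. Within the data shown here, the one measured step that touches this same chain end, an at least 20-fold lower number from compound 2 to compound 3 (1.31 log units; beyond the scatter), shows that exchanging the group on that carbon moves the number far, with the larger group sitting at the limit (the limit of > 20000 nM in this assay, at which 1 of the 3 values shown sits). The entering piperidin-1-yl again enlarges that end. For compound 4 a step of a 2.1-fold higher number from compound 3 to compound 4 (0.31 log units; beyond the scatter) toward a higher number is therefore expected. Compound 4 is estimated at 2000 nM, between 500 nM and 8000 nM.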

Compound 4, half-maximal inhibitory concentration: 380 nM
Compound 4: middle estimate off by 5.3-fold (0.72 log units), on the high side; measured number below the stated range.
By their numbers in this assay, from the lowest: compound 4; then compound 3; then compound 1. At a limit, above all of these: compound 2.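

In this assay, piperidin-1-yl in place of methyl on a saturated ring carbon gives a 2.6-fold lower number from compound 3 to compound 4 (0.41 log units; beyond the scatter), so a larger group at this chain end does not by itself raise the number. Compound 2 stands at a limit, which is not a number: the limit of > 20000 nM in this assay, at which 1 of the 4 values shown sits.
Even so, the group with more heavy atoms gives an at least 52-fold lower number from compound 2 to compound 4 (1.72 log units; beyond the scatter), so size alone does not set the order here.

The compounds shown leave open whether the entering ring nitrogen or the added ring carries the gain. Cyclohexyl, morpholin-4-yl or dimethylamino on that carbon would separate the two.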